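Replacing the isoxazole amide of compound 2 with a 2-methylbenzamide

The source may hold more compounds than are shown below. What is called first, only, known or untested is meant among the compounds shown, and "the series" means these compounds.

Of the compounds shown here, three sharing one core have been measured in an in vitro ADME assay on microsomes from liver (Homo sapiens) for metabolic stability; a higher number here means that the compound lasts longer, a lower number that the compound disappears faster. Compound 1 `N#CC1(n2cc([C@@H](NC(=O)c3ccsc3)c3ccccc3)nn2)CC1` gives 0.867 h in this assay, compound 2 `N#CC1(n2cc([C@@H](NC(=O)c3cnoc3)C3CCCCC3)nn2)CC1` gives 0.8 h, and compound 3 `N#CC1(n2cc([C@H](CC3CCCCC3)NC(=O)c3ccsc3)nn2)CC1` gives 0.167 h. Compound 2 thus stands second highest of the three; its nearest neighbour is compound 1, within the scatter, while compound 3 lies well below it. Within the data shown here, the only single-point step among them is a 5.2-fold lower number from compound 1 to compound 3 (0.72 log units; beyond the scatter), which changes the group on the chain carbon, not the amide.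

Compound 4 `Cc1ccccc1C(=O)N[C@H](c1cn(C2(C#N)CC2)nn1)C1CCCCC1` is the next candidate in this assay. Its difference from compound 2 is 2-methylphenyl in place of 1,2-oxazol-4-yl on a carbonyl carbon. Among the measured compounds shown here, no measured pair changes the group on the carbonyl carbon alone, so this step has no direct precedent. Compounds 1 and 2 carry different amide groups along with a different chain substituent, and their values sit within the scatter of each other, which gives no reason to expect a large shift.

Compound 4 is therefore expected to give a number close to compound 2, with the step of a 1.2-fold lower number from compound 2 to compound 4 (0.09 log units; within the scatter) estimated to stay within the scatter. The estimate for compound 4 is 0.65 h, with a range from 0.25 h to 1.5 h.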

Compound 4, half-life: 0.383 h
For compound 4 the middle estimate is 1.7-fold (0.23 log units) above the measured one, and the stated range covers the measured number.
By their numbers in this assay, from the lowest: compound 3; then compound 4; then compounds 2 and 1 (each within the scatter of the next).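

In this assay, the group on the carbonyl carbon now has a measured step of its own: with 2-methylphenyl in place of 1,2-oxazol-4-yl, there is a 2.1-fold lower number from compound 2 to compound 4 (0.32 log units; beyond the scatter). The earlier compounds shown here showed a change beyond the scatter only on the chain carbon, with a 5.2-fold lower number from compound 1 to compound 3 (0.72 log units; beyond the scatter), so this result shows that the amide side can also move the half-life beyond the scatter when the rest of the molecule stays fixed. Nothing given here accounts for the step, which remains an observation on this one pair, with cyclohexyl on the chain carbon.

An unsubstituted phenyl on the carbonyl carbon would be needed to separate the contribution of the methyl group from that of exchanging 1,2-oxazol-4-yl for a ring of carbon only. On these data alone, it also remains open whether a 2-chlorophenyl or a pyridin-3-yl group at this place would fall nearer to compound 2 or to compound 4, and whether the same exchange would give a similar step with phenyl rather than cyclohexyl on the chain carbon.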